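Chloro for trifluoromethyl carried from one core to another

This account rests on a few compounds, and the source may have more. Where it says the series, first, only, none or still open, it means among the compounds named here.

Compound 2 `N#Cc1ccc(NC(=O)c2ccc(C(F)(F)F)cc2O)cc1` and compound 1 `N#Cc1ccc(NC(=O)c2ccc(Cl)cc2O)cc1` share a core and differ only as chloro in place of trifluoromethyl on an aromatic carbon. In a functional assay on KG-1 cells (Homo sapiens) for cytotoxicity, read by luminescence and CellTiter-Glo, with a stated time of 3 days (a lower number here means a stronger inhibitor, a higher number a weaker inhibitor), compound 2 gives 1440 nM and compound 1 gives 1920 nM; the step is a 1.3-fold higher number from compound 2 to compound 1 (0.12 log units; within the scatter). Compound 3 `O=C(Nc1ccc(C(F)(F)F)cc1)c1ccc2cccnc2c1O` gives 3510 nM in this assay; the difference between its core and the core of compound 2 is not broken down here. Compound 4 `O=C(Nc1ccc(Cl)cc1)c1ccc2cccnc2c1O` is unmeasured and differs from compound 3 as chloro in place of trifluoromethyl on an aromatic carbon. This is the same kind of change as that from compound 2 to compound 1, not the same: for compound 2 and compound 1 the place is also meta to a hydroxy group (1 heavy atom), which is absent from the place in compound 3 and compound 4. The step from compound 3 to compound 4 is expected to be a 1.2-fold higher number from compound 3 to compound 4 (0.08 log units; within the scatter), resting on a 1.3-fold higher number from compound 2 to compound 1 (0.12 log units; within the scatter). Compound 4 is therefore estimated at 4200 nM in this assay, between 2000 nM and 9000 nM.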

Compound 4, half-maximal inhibitory concentration: 3300 nM
Beside the measured number, compound 4's estimate is 1.3-fold (0.10 log units) above it; the measured number falls inside the stated range.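

In this assay the new step is a 1.1-fold lower number from compound 3 to compound 4 (0.03 log units; within the scatter), so chloro in place of trifluoromethyl again leaves the number within the scatter. The change carries from one core to the other without a difference that can be read: the same change on two cores in this assay, a 1.3-fold higher number (0.12 log units; within the scatter) from compound 2 to compound 1 and a 1.1-fold lower number (0.03 log units; within the scatter) from compound 3 to compound 4, 1.4-fold (0.15 log units) apart, within the scatter of two such steps. Among these compounds, this shows only that both steps are too small to separate from repeat scatter in this cell assay; two pairs set no rule for the series and say nothing of further cores.

Only chloro and trifluoromethyl are shown at the changed place, so an amine, a methoxy group or a carboxylic acid there remains open. Going by these compounds, whether the two steps also agree in any assay other than this assay stays open as well.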